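Adding a Second Chloro Group to Compound 3

A few compounds are considered here, and "the series" means these few. Any claim that something is new, unique, unknown or untested is made for them only; others in the source may bear on it.

Compound 3 `CN(C)CCNc1nc(-c2ccc(NC(=O)Nc3ccccc3Cl)cc2)nc2ccsc12` gives 850 nM in a functional assay on MKN-45 cells (Homo sapiens) for cytotoxicity, read by MTT assay, with a stated time of 72 h (on this read-out higher numbers stand for weaker inhibition and lower numbers for stronger inhibition), the second highest of the three numbers shown. Going by the values given here, compound 2 `CN(C)CCNc1nc(-c2ccc(NC(=O)Nc3ccc(Cl)cc3)cc2)nc2ccsc12` gives 250 nM, and the change a 3.4-fold higher number from compound 2 to compound 3 (0.53 log units; beyond the scatter) shows that moving the single chloro group shifts the number beyond the scatter. Compound 1 `CN(C)CCCNc1nc(-c2ccc(NC(=O)Nc3ccc(Cl)cc3Cl)cc2)nc2ccsc12` gives 2270 nM; it carries the same 2,4-dichlorophenyl group that compound 4 will carry but differs elsewhere, so it only hints at the outcome. Compound 4 `CN(C)CCNc1nc(-c2ccc(NC(=O)Nc3ccc(Cl)cc3Cl)cc2)nc2ccsc12` differs from compound 3 by chloro in place of hydrogen on an aromatic carbon. Among the compounds with values here, no measured step covers this exact change, so the expectation is uncertain; a modest rise toward the number of compound 1 is expected, a 1.3-fold higher number from compound 3 to compound 4 (0.11 log units; within the scatter). Compound 4 is estimated at 1100 nM, in a range from 400 nM to 3000 nM.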

Compound 4, half-maximal inhibitory concentration: 2360 nM
Compound 4: middle estimate off by 2.1-fold (0.33 log units), on the low side, within the range that was stated.
By their numbers in this assay, from the lowest: compound 2; then compound 3; then compounds 1 and 4 (each within the scatter of the next).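

Adding a second chloro group weakens inhibition from either single-chloro compound: 2-chlorophenyl to 2,4-dichlorophenyl gives a 2.8-fold higher number from compound 3 to compound 4 (0.44 log units; beyond the scatter) and the change from 4-chlorophenyl gives a 9.4-fold higher number from compound 2 to compound 4 (0.97 log units; beyond the scatter) on this read-out. With the 2,4-dichlorophenyl group in place, the dimethylamino chain of compound 4 and the longer one of compound 1 show no real difference, with a 1.0-fold higher number from compound 1 to compound 4 (0.02 log units; within the scatter) in the data. Nothing available explains these shifts. Still open, on these data alone, is whether fluoro, methyl or methoxy at this place would behave like chloro, and how an unsubstituted phenyl compares.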